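The source may hold more compounds than are shown below. What is called first, only, known or untested is meant among the compounds shown, and "the series" means these compounds.

Compound 1 `O=C(Nc1ncc(Cc2cccc(C(F)(F)F)c2)s1)c1ccc2ccccc2c1` carries a naphthalene amide on the shared core. In an assay on microsomes for inhibition of acyl-CoA desaturase 1 (Mus musculus), with a stated time of 60 min (a higher number here means a weaker inhibitor, a lower number a stronger inhibitor), compound 1 reaches only the limit of the assay, > 10000 nM, which is a limit and not a number (the limit of > 10000 nM in this assay, at which 1 of the 3 values shown sits). Compound 2 `COc1ccc(C(=O)Nc2ncc(Cc3cccc(F)c3)s2)cc1OCCO` and compound 3 `COc1ccc(C(=O)Nc2ncc(Cc3cccc(Cl)c3)s2)cc1OCCO` share a different amide and differ only in the halogen on the benzyl ring. In this assay compound 2 gives 2 nM. Compound 3 gives 1 nM; of the two numbers shown it is the lower one, but the step of a 2.0-fold lower number from compound 2 to compound 3 (0.30 log units; within the scatter) is within the scatter, so compound 2 and compound 3 cannot be told apart.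

Compound 4 `COc1ccc(C(=O)Nc2ncc(Cc3cc(Cl)cc(Cl)c3)s2)cc1OCCO` follows from compound 3 by one change: chloro in place of hydrogen on an aromatic carbon. Going by the values given here, the only measured step that bears on it, the step from compound 2 to compound 3, exchanged one halogen for another at this ring and stayed within the scatter; no measured pair adds a second substituent. Compound 4 is therefore expected to remain close to compound 3, with an estimated step of a 1.5-fold higher number from compound 3 to compound 4 (0.18 log units; within the scatter) in this assay. The estimate for compound 4 is 1.5 nM, within 0.4 nM to 6 nM.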

Compound 4, half-maximal inhibitory concentration: 0.7 nM
Compound 4: the middle estimate sits 2.1-fold (0.33 log units) above what was measured; the range from low to high includes it.
By their numbers in this assay, from the lowest: compounds 4, 3 and 2 (each within the scatter of the next, the first and the last beyond it). At a limit, above all of these: compound 1.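

In this assay, going by these compounds alone, the earlier compounds only exchanged one halogen for another on the benzyl ring, whereas compound 4 shows that this ring also accepts a second chloro, meta to the first, with a 1.4-fold lower number from compound 3 to compound 4 (0.15 log units; within the scatter). Set against the single fluoro of compound 2, the 3,5-dichlorobenzyl group gives a 2.9-fold lower number from compound 2 to compound 4 (0.46 log units; beyond the scatter), the only step among these three compounds that clears the scatter, and a modest one. Nothing shown gives a cause for either step.

Going by these compounds, whether a methoxy group, a nitrile or an amine at this aromatic carbon would hold these numbers stays open. Compound 1 differs from the others at both the amide and the benzyl ring, and the compounds shown do not separate those two places.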